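The source may report more compounds than this note shows. Statements on the series, on what has been measured and on what is new or still open speak of the compounds shown alone.

Measured so far in an assay on isolated protein for binding affinity to leukotriene B4 receptor 1 (Homo sapiens), tested at 1 uM; a lower number here means less inhibition, a higher number more inhibition at the concentration tested (going by the name of the read-out):
compound 1 `CCc1cc(C(C)=O)c(O)cc1OCCCCC(C)(C)C#N` gives 30%;
compound 2 `CCc1cc(C(C)=O)c(O)cc1OCCCC(C)(C)C(=O)O` gives 43%;
compound 3 `CCc1cc(C(C)=O)c(O)cc1OCCCCCCSC` gives 14%.

Among these three, compound 3 stands lowest. The step of a number 16 percentage points lower from compound 1 to compound 3 (beyond the scatter) and the step of a number 29 percentage points lower from compound 2 to compound 3 (beyond the scatter) both end at compound 3, and each lies beyond the scatter, so its place at the bottom is not in doubt.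

Compound 4 `CCc1cc(C(C)=O)c(O)cc1OCCCCCCC(=O)N(C)C` differs from compound 3 by a single change: dimethylcarbamoyl in place of methylsulfanyl on a saturated chain carbon, six bonds along the chain from an oxygen on an aromatic ring. Both measured steps into compound 3 bear on this change, since each of them exchanged a group carrying a nitrile or a carboxylic acid on the chain for the methylsulfanyl group and lowered the inhibition by a modest amount. Read backwards, leaving methylsulfanyl for a group that carries one hydrogen-bond acceptor raised inhibition in both cases. Among the measured compounds shown here, the dimethylcarbamoyl group likewise carries one hydrogen-bond acceptor, but no measured compound holds this exact group, so the size of the effect is uncertain. A modest rise beyond the scatter is expected, a number 16 percentage points higher from compound 3 to compound 4 (beyond the scatter). Compound 4 is therefore estimated at 30%, with a range from 15% to 50%.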

Compound 4, a percentage reported as inhibition, at one concentration (the size of the read-out at that concentration, not a potency): 61%
For compound 4 the middle estimate is 31 percentage points below the measured one, and the stated range ends below it.
By their numbers in this assay, from the lowest: compound 3; then compound 1; then compound 2; then compound 4.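

In this assay, the end of this chain responds strongly to what it carries: dimethylcarbamoyl in place of methylsulfanyl gives a number 47 percentage points higher from compound 3 to compound 4 (beyond the scatter), although both groups have the same counts of hydrogen-bond donors and acceptors, so those counts alone do not follow the step. The dimethylcarbamoyl chain also surpasses the chains ending in a carboxylic acid and a nitrile, with a number 18 percentage points higher from compound 2 to compound 4 (beyond the scatter) and a number 31 percentage points higher from compound 1 to compound 4 (beyond the scatter), so the carboxylic acid of compound 2 no longer marks the top of the series and compound 4 stands highest of the four. Nothing available for these compounds gives a reason for this rise.

Still open, as far as these compounds go, is which part of the dimethylcarbamoyl group matters: the same chain ending in an unsubstituted amide, a monomethyl amide or a ketone would separate the contribution of the carbonyl from that of the two methyl groups on nitrogen. Also open, from the compounds shown here alone, is the role of chain length, which a shorter or longer chain carrying the same dimethylcarbamoyl group would test.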